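Dichlorophenyl Triazole Analog of a Quinoline Ether Amide

The compounds below may be only part of what the source reports. "The series", "measured", "known", "first", "only" and "open" are said of these compounds alone.

The measured compounds:
compound 1 `COc1cc2c(Oc3ccc(NC(=O)c4cn(-c5ccccc5)nn4)cc3F)ccnc2cc1OCCCN1CCCCC1` with 180 nM
compound 2 `COc1cc2c(Oc3ccc(NC(=O)c4cn(-c5ccc(Br)cc5)nn4)cc3F)ccnc2cc1OCCCN1CCCCC1` with 260 nM

Compound 1 gives the lower of the two numbers in a functional assay on HT-29 cells (Homo sapiens) for cytotoxicity, read by MTT assay, with a stated time of 72 h; a higher number here means a weaker inhibitor, a lower number a stronger inhibitor; its nearest neighbour is compound 2, and the step of a 1.4-fold higher number from compound 1 to compound 2 (0.16 log units; within the scatter) is the only measured one. That step, bromo in place of hydrogen on an aromatic carbon, changes the same phenyl group that is altered in compound 3 `COc1cc2c(Oc3ccc(NC(=O)c4cn(-c5c(Cl)cccc5Cl)nn4)cc3F)ccnc2cc1OCCCN1CCCCC1`, where the change is 2,6-dichlorophenyl in place of phenyl on an aromatic nitrogen. Within the data shown here, no measured step carries two chlorines on that ring, so the bromo step gives only a loose guide: a small move, in either direction or none beyond the scatter. Compound 3 is therefore expected at 300 nM, within 110 nM to 850 nM, a step of a 1.7-fold higher number from compound 1 to compound 3 (0.22 log units; within the scatter) that is estimated, not measured.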

Compound 3, half-maximal inhibitory concentration: 240 nM
For compound 3 the middle estimate is 1.3-fold (0.10 log units) above the measured one, within the range that was stated.
By their numbers in this assay, from the lowest: compounds 1, 3 and 2 (each within the scatter of the next).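

In this assay, 2,6-dichlorophenyl in place of phenyl on the aromatic nitrogen gives a 1.3-fold higher number from compound 1 to compound 3 (0.12 log units; within the scatter), so this position accepts a phenyl group carrying two chlorines with no change beyond the scatter. Against the 4-bromophenyl group, the same 2,6-dichlorophenyl group gives a 1.1-fold lower number from compound 2 to compound 3 (0.03 log units; within the scatter), and the two substituted phenyl groups cannot be told apart here. No independent evidence bears on this result. The compounds shown leave open how an amine, a carboxylic acid or a nitrile on this phenyl ring would read, and whether a cyclohexyl group could replace the ring itself.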